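This account rests on a few compounds, and the source may have more. Where it says the series, first, only, none or still open, it means among the compounds named here.

Measured so far:
compound 1 `O=C(CCCCC1CCSS1)NCc1cn(CCCOc2ccc3ccc(=O)oc3c2)nn1`: 43.5%
compound 2 `CCOC(=O)c1cc2ccc(OCCCn3cc(CNC(=O)CCCCC4CCSS4)nn3)cc2oc1=O`: 49.2%

In a functional assay on PC-12 cells (Rattus norvegicus) for cytotoxicity, read by MTT assay, with stated times of 3 h and 2 h, tested at 50 uM (a lower number here means a weaker effect, a higher number a stronger effect of the compound at the concentration tested), compound 1 gives 43.5%, the lower of the two numbers. Within the data shown here, compound 2 gives 49.2%, and the only step between measured compounds, a number 5.7 percentage points higher from compound 1 to compound 2 (within the scatter), replaced hydrogen on an aromatic carbon of the shared core. Compound 3 `O=C(CCCCC1CCSS1)NCc1cn(CCCOc2ccc3cc(-c4ccc(Cl)cc4)c(=O)oc3c2)nn1` differs from compound 1 by 4-chlorophenyl in place of hydrogen on an aromatic carbon. That one step bears on this change only loosely, and it stayed within the scatter, so no step beyond the scatter is expected in this assay. Compound 3 is estimated at 47% (range 35% to 60%), an expected step of a number 3.5 percentage points higher from compound 1 to compound 3 (within the scatter).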

Compound 3, a percentage reported as activity, at one concentration (the size of the read-out at that concentration, not a potency): 79.4%
The estimate for compound 3 lay 32.4 percentage points below the measured number; the whole stated range lies below it.
By their numbers in this assay, from the lowest: compounds 1 and 2 (each within the scatter of the next); then compound 3.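

In this assay, the aromatic carbon two atoms from the ring oxygen proved able to carry a step beyond the scatter: 4-chlorophenyl in place of hydrogen gave a number 35.9 percentage points higher from compound 1 to compound 3 (beyond the scatter). Ethoxycarbonyl on the same carbon had not done so, and 4-chlorophenyl in its place gave a number 30.2 percentage points higher from compound 2 to compound 3 (beyond the scatter). The outcome at this carbon therefore depends on which group enters, not merely on the carbon being substituted. Nothing measured here accounts for the difference. From the compounds shown here alone, whether the chlorine or the phenyl ring carries the step remains open, as does how an unsubstituted phenyl or an aminomethyl group would read on this carbon.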